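Trading a Fluorophenyl for a Trifluoromethylphenyl Group

The source may report more compounds than this note shows. Statements on the series, on what has been measured and on what is new or still open speak of the compounds shown alone.

In a functional assay on A-375 cells (Homo sapiens) for activation, with a stated time of 3 days (a higher number here means that more compound is needed for the effect, a lower number that less compound is needed), three compounds have been measured so far. Compound 1 `O=C(Nc1ccc2scnc2c1)C1CCCN(Cc2ccc(F)c(F)c2)C1` gives > 20000 nM, which is a limit of the assay and not a number. Compound 2 `O=C(Nc1ccc(-c2cscn2)cc1)[C@@H]1CCCN(Cc2ccc(F)c(F)c2)C1` gives 4000 nM. Compound 3 `O=C(Nc1ccc(-c2cscn2)cc1)C1CCCN(Cc2ccc(F)cc2)C1` gives 5000 nM, and this lies within the usual scatter of the value for compound 2, so the two cannot be told apart.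

The next compound is compound 4 `O=C(Nc1ccc(-c2cscn2)cc1)C1CCCN(Cc2cccc(C(F)(F)F)c2)C1`. It carries 3-(trifluoromethyl)phenyl in place of 4-fluorophenyl on a saturated chain carbon bound to an amine nitrogen in a ring. Among the compounds with values here, no measured pair yet shows what such a swap does in this assay, so no step beyond the scatter is expected, in either direction. The expectation therefore stays close to compound 3 at 5000 nM. The expected change is a 1.3-fold lower number from compound 3 to compound 4 (0.10 log units; within the scatter). For compound 4 the estimated value is 4000 nM, with an expected range from 1500 nM to 12000 nM.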

Compound 4, half-maximal effective concentration: > 20000 nM
Compound 4: only a limit was reported; the forecaster's own chance of this, stated with the estimate: 15%; middle value at least 5.0-fold (0.69 log units) from the limit.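

In this assay, the group on a saturated chain carbon bound to an amine nitrogen in a ring proves sensitive to change: placing 3-(trifluoromethyl)phenyl there in place of 4-fluorophenyl gives an at least 4.0-fold higher number from compound 3 to compound 4 (0.60 log units; beyond the scatter). Within the data shown here, this is the only step between compounds differing in one place so far, and it shows that this change means more compound is needed for the effect. Compound 4 carries a limit of the assay and not a number, so the step shows only the smallest size the change can have: the limit of > 20000 nM in this assay, at which 2 of the 4 values shown sit.

The swap alters both the substituent and where it sits on the phenyl ring, so the compounds shown cannot tell which of the two matters. They also leave open how a chlorine atom or a methoxy group on that phenyl ring would behave in this assay.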